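Hydrogen in Place of Methoxy: An Expected Paw Edema Result

The source may hold more compounds than are shown below. What is called first, only, known or untested is meant among the compounds shown, and "the series" means these compounds.

Compound 1, `COc1cc(-c2nnc(SCC(=O)Nc3ccc(/C(C)=N/O)cc3)n2-c2ccccc2)cc(OC)c1OC`, in a functional assay on the whole organism (strain albino) for inhibition, with Rattus norvegicus as the target, read by paw edema, with stated times of 30 min and 5 h, at a dose of 0.28 mmol/kg by the oral route (on this read-out lower numbers stand for less inhibition and higher numbers for more inhibition at the one dose given (going by the name of the read-out)), gives 70%.
Compound 2, `CCn1c(SCC(=O)Nc2ccc(/C(C)=N/O)cc2)nnc1-c1ccc(OC)cc1`, in this assay gives 65%.
Compound 3, `COc1ccc(-c2nnc(SCC(=O)Nc3ccc(/C(C)=N/O)cc3)n2-c2ccccc2)cc1OC`, in this assay gives 76%.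

Compound 4, `CCn1c(SCC(=O)Nc2ccc(/C(C)=N/O)cc2)nnc1-c1ccccc1`, has not yet been measured in this assay. It differs from compound 2 by hydrogen in place of methoxy on an aromatic carbon. The same kind of change separates the measured pair compound 1 and compound 3, namely (hydrogen in place of methoxy on an aromatic carbon), though the surroundings of the place differ: in compound 2 the group sits para to a large group, while in compound 1 it sits ortho to a methoxy group, meta to a large group and meta to a methoxy group. The difference between the cores of compound 1 and compound 2 is not broken down here.

Among the measured compounds, compound 2 and compound 1 lie within the scatter of each other, and compound 3 is higher than compound 2 by more than the scatter. For the measured pair the change gave a number 6 percentage points higher from compound 1 to compound 3 (within the scatter).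

Compound 4 is therefore expected to give about 67%, with a range from 54% to 79%. The step from compound 2 to compound 4 is expected to be a number 2 percentage points higher from compound 2 to compound 4 (within the scatter). This expectation rests on the step of a number 6 percentage points higher from compound 1 to compound 3 (within the scatter), the only other occurrence of this kind of change among these compounds, and on the value of compound 2, 65%, as the starting point.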

Compound 4, a percentage reported as inhibition, in the whole organism at one dose (the size of the read-out at that dose, not a potency): 66%
For compound 4 the middle estimate is 1 percentage points above the measured one; measured number inside the range.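

In this assay, hydrogen in place of methoxy, here the change from 4-methoxyphenyl to phenyl, gave a number 1 percentage points higher from compound 2 to compound 4 (within the scatter), so the new step stays as small as the scatter allows it to be read. Set beside the earlier case, the two steps do not differ, and on these two cores the change behaves alike: the same change on two cores in this assay, a number 6 percentage points higher (within the scatter) from compound 1 to compound 3 and a number 1 percentage points higher (within the scatter) from compound 2 to compound 4, 5 percentage points apart, within the scatter of two such steps. For the compounds shown here, this shows only that removing a methoxy group from the aromatic ring moved the paw edema number beyond the scatter on neither core; it does not show that the methoxy group is without any effect, since a small effect could lie hidden in the scatter, and two cores, with the change in different surroundings and read at a single dose, do not establish a rule for the whole series.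

The compounds shown leave open what other groups would do at the place para to a large group, for example a chlorine atom, an amine, a carboxylic acid or a longer chain in place of the methoxy group. They also leave open whether the agreement between the two steps would hold on a further core, or at doses other than the one given.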